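Removing the ester from a cyanoaziridine urea

The compounds below may be only part of what the source reports. "The series", "measured", "known", "first", "only" and "open" are said of these compounds alone.

The compounds measured so far:
compound 1, `CCOC(=O)c1ccc(NC(=O)N2CC2C#N)cc1`: 5800 nM
compound 2, `CCCCNC(=O)N1CC1C#N`: 15000 nM
compound 3, `N#CC1CN1C(=O)Nc1cccnc1`: 12000 nM

All three share a core in which a urea carries a three-membered ring bearing a nitrile, and they differ only in the group on the other urea nitrogen. In a functional assay on A-375 cells (Homo sapiens) for inhibition (a higher number here means a weaker inhibitor, a lower number a stronger inhibitor), compound 1 gives the lowest number of the three, so it is the strongest inhibitor here; compound 3 comes nearest, and compound 2 lies furthest away, both beyond the usual scatter.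

Compound 4, `N#CC1CN1C(=O)Nc1ccccc1`, has not yet been measured. It differs from compound 1 in one place: hydrogen in place of ethoxycarbonyl on an aromatic carbon. The ester of compound 1 is simply gone, and the remaining phenyl urea stands between compound 1 and the pyridine of compound 3 in its makeup.

Since compound 3, without the ester, gives a higher number than compound 1, the expected step of a 1.6-fold higher number from compound 1 to compound 4 (0.19 log units; within the scatter) is a modest rise, possibly within the scatter. Compound 4 is expected to give about 9000 nM, in a range from 4000 nM to 25000 nM.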

Compound 4, half-maximal inhibitory concentration: 11000 nM
Estimate against measurement, compound 4: 1.2-fold (0.09 log units) below; measured number inside the range.
By their numbers in this assay, from the lowest: compounds 1, 4, 3 and 2 (each within the scatter of the next, the first and the last beyond it).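

Going by these compounds alone, replacing the ethoxycarbonyl with hydrogen on an aromatic carbon gives, in this assay, a 1.9-fold higher number from compound 1 to compound 4 (0.28 log units; within the scatter), and this is the first comparison of compounds that differ in only one place. The ethoxycarbonyl can therefore be removed without a change that stands clear of the normal variation between repeated measurements, so this pair offers no firm sign that the group matters for this read-out. No measurement is available that would explain this result.

Still open, as far as these compounds go, is whether a different group at this same place, such as a carboxylic acid, an amine or a longer alkyl chain, would move the number beyond the scatter. A single replacement also cannot show whether the same small step would appear on a compound with a different group on the other urea nitrogen.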